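Removing a Chloro Group from a Rotarod-Active Amide

The source may hold more compounds than are shown below. What is called first, only, known or untested is meant among the compounds shown, and "the series" means these compounds.

Of the compounds shown here, three have been tested in a functional assay on the whole organism with Mus musculus as the target, in the rotarod test; on this read-out higher numbers stand for an effect only at larger amounts of compound and lower numbers for an effect already at smaller amounts. Compound 1, `NCC(=O)NCc1nncn1-c1ccc(Cl)cc1C(=O)c1ccccc1`, gives 11.8 mg/kg. Compound 3, `Cc1nnc(CNC(=O)CN)n1-c1ccc(Cl)cc1C(=O)c1ccccc1Cl`, gives 2.09 mg/kg. Compound 2, `CN(C(=O)CNC(=O)CN)c1ccc(Cl)cc1C(=O)c1ccccc1Cl`, gives 35.4 mg/kg, the highest of the three numbers: compound 1 lies nearest, and compound 3 furthest away, both beyond the scatter. The two compounds with a chloro group on the same ring, compound 2 and compound 3, thus show very different values, so that group alone does not fix the outcome.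

The next compound, compound 4, `CN(C(=O)CNC(=O)CN)c1ccc(Cl)cc1C(=O)c1ccccc1`, differs from compound 2 in one spot: hydrogen in place of chloro on an aromatic carbon. Within the data shown here, no directly comparable pair has been measured, so the direction of this change is open. Compound 1, which also carries a plain phenyl, is more potent than compound 2, but its core differs, so it cannot settle the question. A modest step from compound 2 to compound 4 in this assay is expected, a 1.4-fold higher number from compound 2 to compound 4 (0.15 log units; within the scatter), towards a somewhat higher number. Compound 4 is estimated at 50 mg/kg, within a range from 15 mg/kg to 160 mg/kg.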

Compound 4, dose for half-maximal effect: 29.3 mg/kg
The estimate for compound 4 lay 1.7-fold (0.23 log units) above the measured number, and the stated range covers the measured number.
By their numbers in this assay, from the lowest: compound 3; then compound 1; then compounds 4 and 2 (each within the scatter of the next).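

Among these compounds, this pair gives the first direct reading of the chloro group at this place, ortho to a large group: in this assay the change from 2-chlorophenyl to phenyl gives a 1.2-fold lower number from compound 2 to compound 4 (0.08 log units; within the scatter) and so cannot be told apart from repeat scatter. Among the compounds shown here, on the shared core of compound 2 and compound 4, then, the chloro group is not needed for the effect seen in the whole animal, something the earlier compounds, which all differ in more than one place, could not show. Nothing measured here speaks to why the two compounds read alike.

From the compounds shown here alone, whether the chloro group matters as little on the core of compound 3 stays open. So does whether a fluoro, methoxy or nitrile group at this same place would read the same or shift the number beyond the scatter.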